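Cyano in place of sulfamoyl on the shared core

A few compounds are considered here, and "the series" means these few. Any claim that something is new, unique, unknown or untested is made for them only; others in the source may bear on it.

Measured so far in a functional assay on COLO 205 cells (Homo sapiens) for antiproliferative activity, read by sulforhodamine B assay, with a stated time of 72 h (on this read-out higher numbers stand for weaker inhibition and lower numbers for stronger inhibition), for two compounds
Compound 1 `Fc1ccc(Nc2nncc3ccccc23)cc1` gives 4.5 nM
Compound 2 `NS(=O)(=O)c1ccc(Nc2nncc3ccccc23)cc1` gives 23 nM

Compound 2 holds the higher of the two numbers, so it is the weaker inhibitor of the pair. Compound 3 `N#Cc1ccc(Nc2nncc3ccccc23)cc1` is still unmeasured and differs from compound 2 in one group, as cyano in place of sulfamoyl on an aromatic carbon shows, with cyano in place of sulfamoyl on an aromatic carbon, para to a large group. Among the measured compounds shown here, the one measured step on this carbon is a 5.1-fold higher number from compound 1 to compound 2 (0.71 log units; beyond the scatter) and it is modest. For the measured compounds named here, no step involving cyano has been measured, so the expectation rests on that single step, with part of it given back. A modest move to a lower number is therefore expected in this assay and it may lie close to the scatter. The estimate means a 2.3-fold lower number from compound 2 to compound 3 (0.36 log units; beyond the scatter) as the expected step. Expected for compound 3 is 10 nM with 3 nM to 35 nM as the estimated range.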

Compound 3, half-maximal inhibitory concentration: 2.5 nM
Compound 3: the middle estimate sits 4.0-fold (0.60 log units) above what was measured, and the stated range ends above it.
By their numbers in this assay, from the lowest: compounds 3 and 1 (each within the scatter of the next); then compound 2.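

In this assay, cyano in place of fluoro on the aromatic carbon para to a large group gives a 1.8-fold lower number from compound 1 to compound 3 (0.26 log units; within the scatter) and leaves compounds 1 and 3 unranked. Cyano in place of sulfamoyl gives a 9.2-fold lower number from compound 2 to compound 3 (0.96 log units; beyond the scatter) at the same carbon, so the higher number of compound 2 goes with sulfamoyl and does not follow every replacement of fluoro there. No measurement available here explains the gap between sulfamoyl and cyano.

Open, as far as these compounds go, is whether the low numbers of compounds 1 and 3 extend to other groups at this carbon, such as an amine, a carboxylic acid or a methoxy group. Also open, from the compounds shown here alone, is how any of the three groups behaves at another carbon of the same ring, or with the shared core changed.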